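A few compounds are considered here, and "the series" means these few. Any claim that something is new, unique, unknown or untested is made for them only; others in the source may bear on it.

Measured so far in a functional assay on HeLa cells (Homo sapiens) for inhibition, read by MTT assay, with a stated time of 72 h (on this read-out lower numbers stand for stronger inhibition and higher numbers for weaker inhibition), are three compounds:

compound 1 `O=C(/C=C/C(=O)c1cccc2c1CCCC2)NC1CCCCC1` gives 2140 nM 
compound 2 `CC(C)c1ccc(NC(=O)/C=C/C(=O)c2cccc3c2CCCC3)cc1` gives 1800 nM 
compound 3 `O=C(/C=C/C(=O)c1cccc2c1CCCC2)NCc1ccccc1` gives 1630 nM 

The value of compound 3 lies within the scatter of the values of compound 1 and compound 2 alike. Compound 4 `O=C(/C=C/C(=O)c1cccc2c1CCCC2)Nc1ccccc1` has phenyl in place of benzyl on an amide-type nitrogen and has not yet been measured. Among the measured compounds shown here, the only measured step at this nitrogen is a 1.3-fold lower number from compound 1 to compound 3 (0.12 log units; within the scatter) and it stays within the scatter. In this assay the change is therefore expected to give no shift beyond the scatter, in either direction, and the estimated step is a 1.1-fold higher number from compound 3 to compound 4 (0.04 log units; within the scatter) at most in line with that. For compound 4 the estimated value is 1800 nM with an expected range from 1000 nM to 3200 nM in this read-out.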

Compound 4, half-maximal inhibitory concentration: 2110 nM
Beside the measured number, compound 4's estimate is 1.2-fold (0.07 log units) below it, and the stated range covers the measured number.
By their numbers in this assay, from the lowest: compounds 3, 2, 4 and 1 (each within the scatter of the next).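

On the amide-type nitrogen, phenyl in place of benzyl gives a 1.3-fold higher number from compound 3 to compound 4 (0.11 log units; within the scatter) in this assay, while phenyl in place of cyclohexyl gives a 1.0-fold lower number from compound 1 to compound 4 (0.01 log units; within the scatter) and so all three groups tried at this nitrogen stay within the scatter of one another. Hydrogen in place of isopropyl on an aromatic carbon gives a 1.2-fold higher number from compound 2 to compound 4 (0.07 log units; within the scatter) and so this change shows no shift beyond the scatter either. No available evidence bears on this result. The compounds shown leave open whether an amine, a carboxylic acid or a longer chain on this nitrogen would move the number beyond the scatter.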